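Thiourea Cytotoxicity: Methylsulfanylpropyl Replacing Methylallyl

This account rests on a few compounds, and the source may have more. Where it says the series, first, only, none or still open, it means among the compounds named here.

The three measured compounds are:
compound 1, `C=C(C)CNC(=S)Nc1cccc(C(F)(F)F)c1`, which in an ADME assay on MDBK cells (Bos taurus) for cytotoxicity, read by MTT assay, with a stated time of 96 h (on this read-out higher numbers stand for lower toxicity in this test and lower numbers for higher toxicity in this test), gives > 100000 nM;
compound 2, `O=C(NC(=S)Nc1cccc(C(F)(F)F)c1)[C@H]1C[C@@H]2CC[C@H]1C2`, which in this assay gives 10000 nM;
compound 3, `Fc1ccc(NC(=S)Nc2cccc(C(F)(F)F)c2)cc1Cl`, which in this assay gives 11000 nM.

The value for compound 1 is a limit of this assay and not a number, so compound 1 stands at the top of the measured range, (the limit of > 100000 nM in this assay, at which 1 of the 3 values shown sits). Compound 2 and compound 3, which carry a bicyclic amide and a halogenated aryl group on the shared core, both give measured numbers lower than that limit; their two values sit within the scatter of each other.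

Compound 4, `CSCCCNC(=S)Nc1cccc(C(F)(F)F)c1`, differs from compound 1 in one place: 2-(methylsulfanyl)ethyl in place of 1-methylethenyl on a saturated chain carbon bound to an amide-type nitrogen. Both groups are small open chains without rings on the same nitrogen of the shared core. Among the measured compounds shown here, no measured step is available for this kind of change. In this assay the expected step from compound 1 to compound 4 is none beyond the scatter, a number no higher from compound 1 to compound 4 (the limit leaves the size open). Compound 4 is therefore expected to give about 100000 nM, in a range from 30000 nM to 300000 nM, and quite possibly only a limit again.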

Compound 4, half-maximal cytotoxic concentration: > 100000 nM
Compound 4: a limit, no number (the forecaster's own chance of this, stated with the estimate: 55%); the middle value lies on the limit itself.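

In this assay compound 4 gives > 100000 nM, which is a limit of the assay and not a number. Compound 1 also stands at a limit, so no step can be read between compound 1 and compound 4. The compounds shown leave open how far either compound lies past that limit: the limit of > 100000 nM in this assay, at which 2 of the 4 values shown sit.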